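Working notes: bromo in place of fluoro

The source may hold more compounds than are shown below. What is called first, only, known or untested is meant among the compounds shown, and "the series" means these compounds.

Measured values in a functional assay on MCF7 cells (Homo sapiens) for antiproliferative activity, read by colorimetric assay and MTT assay, with a stated time of 48 h (on this read-out lower numbers stand for stronger inhibition and higher numbers for weaker inhibition), are as follows.
- compound 1 (`O=C(NS(=O)(=O)c1ccc(F)cc1)c1cncc(C(=O)NS(=O)(=O)c2ccc(F)cc2)c1`) gives 7900 nM
- compound 2 (`Cc1ccc(S(=O)(=O)NC(=O)c2cncc(C(=O)NS(=O)(=O)c3ccc(C)cc3)c2)cc1`) gives 10800 nM
- compound 3 (`O=C(NS(=O)(=O)c1ccc(F)cc1)c1ccncc1`) gives 13900 nM

Compound 1 and compound 2 both lie within the scatter of compound 3 (13900 nM), so the three numbers support no ranking. Compound 3 therefore stands level with the other two on present data.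

The next compound, compound 4 (`O=C(NS(=O)(=O)c1ccc(Br)cc1)c1ccncc1`), is still unmeasured. Its structure differs from that of compound 3 by one exchange (bromo in place of fluoro on an aromatic carbon): bromo in place of fluoro on an aromatic carbon, para to a large group.

Within the data shown here, no two measured compounds differ in only one place, so the series offers no direct measure of this exchange. The nearest guide is indirect. Compound 1 (7900 nM) and compound 2 (10800 nM) differ in more than one place, yet their values remain within the scatter of each other.

A small shift toward a lower number, not beyond the scatter, is expected (a 1.5-fold lower number from compound 3 to compound 4 (0.17 log units; within the scatter)). Compound 4 is estimated at 9500 nM with an expected range of 4500 nM to 20000 nM in this assay once measured.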

Compound 4, half-maximal inhibitory concentration: 8700 nM
Compound 4: the middle estimate sits 1.1-fold (0.04 log units) above what was measured; low and high end bracket the measured number.
By their numbers in this assay, from the lowest: compounds 1, 4, 2 and 3 (each within the scatter of the next).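

In this assay the pair compound 3 and compound 4 gives the series its first direct reading of a single exchange, bromo in place of fluoro on an aromatic carbon, para to a large group, with a 1.6-fold lower number from compound 3 to compound 4 (0.20 log units; within the scatter). Among these compounds, on the core of compound 3, fluoro and bromo at this place therefore cannot be told apart by this read-out, which the earlier compounds, none differing in only one place, could not show. Nothing at hand bears on why the two groups read alike.

Going by these compounds, whether any other group at this place, such as an amine, a methoxy group or a carboxylic acid, would move the number beyond the scatter stays open. Also open, on these data alone, is whether the same exchange would read alike on the core of compound 1, which carries fluoro as well, so the present reading holds for the core of compound 3 alone.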